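Lengthening one chain when the starting point is a limit

The source may report more compounds than this note shows. Statements on the series, on what has been measured and on what is new or still open speak of the compounds shown alone.

In a functional assay on L1210 cells (Mus musculus) for inhibition, with a stated time of 96 h (a higher number here means a weaker inhibitor, a lower number a stronger inhibitor), compound 1 (`CCNCCCNCCCN`) gives > 100000 nM. This is a limit and not a number, and compound 1 stands at the limit of > 100000 nM in this assay, at which 1 of the 2 values shown sits. Its close relative, compound 2 (`CCCNCCCNCCCN`), gives 100000 nM. Among the compounds with values here, the only measured step reads a number no higher from compound 1 to compound 2 (the limit leaves the size open). That step comes from a different change, methyl in place of hydrogen on a saturated chain carbon, two bonds along the chain from an amine nitrogen, so it is only a loose guide.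

Compound 3 (`CCNCCCNCCCCN`) has not yet been measured. It differs from compound 1 by aminomethyl in place of amino on a saturated chain carbon, three bonds along the chain from an amine nitrogen. The data give no sign of a large gain or loss from a small change to this kind of chain, since compound 2 gives 100000 nM. In this assay, the expected a number no higher from compound 1 to compound 3 (the limit leaves the size open) is no larger than the usual scatter and has no clear direction.

Compound 3 is estimated at 100000 nM, with an expected range from 40000 nM to 250000 nM.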

Compound 3, half-maximal inhibitory concentration: 4000 nM
The estimate for compound 3 lay 25-fold (1.40 log units) above the measured number; measured number below the stated range.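

In this assay, putting aminomethyl in place of amino on a saturated chain carbon, three bonds along the chain from an amine nitrogen, gives an at least 25-fold lower number from compound 1 to compound 3 (1.39 log units; beyond the scatter). Within the data shown here, this shows that the chain at this place responds strongly to a small change: the extra carbon is the only gain in heavy atoms, and the end amine stays in the molecule, yet the step is large, while the one earlier step, a methyl at another place on the chain, cannot be read for size. The full size of the new step also stays unknown because compound 1 stands at a limit and not a number: the limit of > 100000 nM in this assay, at which 1 of the 3 values shown sits.

The compounds shown leave open whether a still longer chain ending in an amine at this place would bring a further drop in the number or give back the gain. They also leave open whether the end amine itself matters, a question that an alcohol or a carboxylic acid in its place, on the same chain as compound 3, would address.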